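The source may report more compounds than this note shows. Statements on the series, on what has been measured and on what is new or still open speak of the compounds shown alone.

Two compounds of the shared core have numbers in an assay on NK92 cells for inhibition of interleukin-15 (Homo sapiens), read by AlphaScreen, with stated times of 30 min and 1 h; on this read-out lower numbers stand for stronger inhibition and higher numbers for weaker inhibition. Compound 1 `Cn1c(Cc2nn(C)c(=O)c3ccccc23)nnc1SCCCCCCCC(=O)Nc1ccc(Cl)cc1Cl` gives 190 nM, the lower of the two, and compound 2 `Cn1nc(Cc2nnc(SCCCCCCCC(=O)Nc3ccc(Cl)cc3Cl)[nH]2)c2ccccc2c1=O` gives 280 nM; the step of a 1.5-fold higher number from compound 1 to compound 2 (0.17 log units; within the scatter) is within the scatter. Compound 3 `CN(C)CCCn1nc(Cc2nnc(SCCCCCCCC(=O)Nc3ccc(Cl)cc3Cl)n2C)c2ccccc2c1=O` differs from compound 1 by 2-(dimethylamino)ethyl in place of hydrogen on a saturated chain carbon bound to an aromatic nitrogen, so that methyl becomes 3-(dimethylamino)propyl. Within the data shown here, no measured step alters this chain; the only step on record, from compound 1 to compound 2, concerns a different aromatic nitrogen and was small. For compound 3 a step of about a 1.1-fold higher number from compound 1 to compound 3 (0.02 log units; within the scatter) is therefore expected, none beyond the scatter. Compound 3 is estimated at 200 nM, between 60 nM and 700 nM.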

Compound 3, half-maximal inhibitory concentration: > 30000 nM
Compound 3 ended at the assay's limit (the forecaster's own chance of this, stated with the estimate: 5%); middle value at least 150-fold (2.17 log units) from the limit.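

Extending methyl to 3-(dimethylamino)propyl on this aromatic nitrogen is not tolerated in this assay: the change gives an at least 150-fold higher number from compound 1 to compound 3 (2.19 log units; beyond the scatter), whereas the only earlier step, a 1.5-fold higher number from compound 1 to compound 2 (0.17 log units; within the scatter), concerned a different aromatic nitrogen. The value of compound 3 is a limit and not a number: the limit of > 30000 nM in this assay, at which 1 of the 3 values shown sits. This position therefore responds sharply to the group it carries, which the earlier pair could not show.

From the compounds shown here alone, whether the loss follows the dimethylamino group or the chain length stays open. A plain propyl group or a shorter 2-(dimethylamino)ethyl chain at this position would separate the two.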